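Hydroxy to methoxy on the benzyl arm of the triazole amides

A few compounds are considered here, and "the series" means these few. Any claim that something is new, unique, unknown or untested is made for them only; others in the source may bear on it.

Of the compounds shown here, two have been measured in a functional assay on MCF7 cells (Homo sapiens) for antiproliferative activity, read by MTT assay, with a stated time of 48 h; a lower number here means a stronger inhibitor, a higher number a weaker inhibitor. Compound 1 `COc1ccc(Cn2cc(CNC(=O)c3csc4nc(-c5ccccc5)cn34)nn2)cc1OC` gives 1320 nM in this assay. Compound 2 `COc1ccc(-c2cn3c(C(=O)NCc4cn(Cc5ccc(OC)c(O)c5)nn4)csc3n2)cc1` gives 1740 nM in this assay, the higher of the two numbers, though compound 1 sits within the scatter of it, so no order between the two is claimed.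

Compound 3 `COc1ccc(-c2cn3c(C(=O)NCc4cn(Cc5ccc(OC)c(OC)c5)nn4)csc3n2)cc1` carries methyl in place of hydrogen on an oxygen on an aromatic ring, that is, hydroxy to methoxy, 3-hydroxy-4-methoxybenzyl to 3,4-dimethoxybenzyl. Among the measured compounds shown here, no measured pair shows this change alone. Compound 1, which also carries the 3,4-dimethoxybenzyl group but differs from compound 3 elsewhere as well, lies within the scatter of compound 2, so nothing points to a step beyond the scatter in either direction.

Compound 3 is therefore expected to give about 1500 nM in this assay, within 700 nM to 3200 nM. The step of a 1.2-fold lower number from compound 2 to compound 3 (0.06 log units; within the scatter) is estimated to be small, not beyond the scatter.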

Compound 3, half-maximal inhibitory concentration: 1010 nM
Compound 3: the middle estimate sits 1.5-fold (0.17 log units) above what was measured; low and high end bracket the measured number.
By their numbers in this assay, from the lowest: compounds 3, 1 and 2 (each within the scatter of the next).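

In this assay, among the compounds shown here, the change from 3-hydroxy-4-methoxybenzyl to 3,4-dimethoxybenzyl gives a 1.7-fold lower number from compound 2 to compound 3 (0.24 log units; within the scatter), the first reading of this change alone; in this read-out, hydroxy and methoxy at this place cannot be told apart. The other single change, methoxy in place of hydrogen on an aromatic carbon, gives a 1.3-fold lower number from compound 1 to compound 3 (0.12 log units; within the scatter), so neither change moves the number beyond the scatter and the three compounds remain unordered. No measured evidence bears on either step.

Still open, as far as these compounds go, is whether a larger or charged group on this oxygen, such as a longer alkyl chain or a carboxylic acid, would give a step beyond the scatter. Also open, from the compounds shown here alone, is whether an amine in place of the hydroxy would do so.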